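Aryl-amine variation on the shared core: notes toward compound 4

The compounds below may be only part of what the source reports. "The series", "measured", "known", "first", "only" and "open" are said of these compounds alone.

Measured compounds:
compound 1 `Cc1n[nH]c2ccc(-c3nc4cnc(N5CCN(C)CC5)cn4c3Nc3cccc(Cl)c3)cc12`: "not determined" (no result reported)
compound 2 `COc1ccc(Nc2c(-c3ccc4[nH]nc(C)c4c3)nc3cnc(N4CCN(C)CC4)cn23)cc1`: 0%
compound 3 `Cc1ccc(C)c(Nc2c(-c3ccc4[nH]nc(C)c4c3)nc3cnc(N4CCN(C)CC4)cn23)c1`: "not determined" (no result reported)

Going by the values given here, compound 3 stands without a number in a functional assay on CWR22R cells (Homo sapiens) for inhibition, with a stated time of 120 h, tested at 10 uM; on this read-out lower numbers stand for less inhibition and higher numbers for more inhibition at the one concentration tested (going by the name of the read-out); the same holds for compound 1, so the only figure in this assay is the one of compound 2. Among the compounds with values here, no step between measured compounds can be drawn.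

Compound 4 `Cc1n[nH]c2ccc(-c3nc4cnc(N5CCN(C)CC5)cn4c3Nc3ccc(Cl)cc3Cl)cc12` differs from compound 3 as follows: 2,4-dichlorophenyl in place of 2,5-dimethylphenyl on a nitrogen on an aromatic ring. Within the data shown here, with compound 3 lacking a value, no step in this assay can be stated for this change, and nothing beyond the scatter is expected from it. Compound 4 is expected to give 10% (range 0% to 35%), because compound 2 gives 0% in this assay.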

Compound 4, a percentage reported as inhibition, at one concentration (the size of the read-out at that concentration, not a potency): 9.53%
Estimate against measurement, compound 4: 0.5 percentage points above; measured number inside the range.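

In this assay, two substituted phenyl groups on the nitrogen can now be compared: 2,4-dichlorophenyl in place of 4-methoxyphenyl gives a number 9.5 percentage points higher from compound 2 to compound 4 (within the scatter), so swapping these two groups at this position does not separate the compounds. Steps to or from compound 1 and compound 3 cannot be read. No measured property bears on this result.

Still open, from the compounds shown here alone, is whether a cyclohexyl group or a pyridine ring on that nitrogen would give a read-out beyond the scatter of these two compounds.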